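The source may hold more compounds than are shown below. What is called first, only, known or untested is meant among the compounds shown, and "the series" means these compounds.

Series on the shared core of compound 1 `Nc1ncnc2c1ncn2CC(O)C(=O)OCCO`, with the group on the oxygen next to the carbonyl varied. In a functional assay on PRK cells (Oryctolagus cuniculus) for cytotoxicity (a higher number here means that more compound is tolerated, a lower number that less compound is tolerated), compound 1 is recorded only as the limit > 400 ug/mL. Compound 2 `CC(C)OC(=O)C(O)Cn1cnc2c(N)ncnc21` likewise stands at the limit > 400 ug/mL in this assay. Going by the values given here, compound 3 `CCCOC(=O)C(O)Cn1cnc2c(N)ncnc21` is the sole member with a read number, giving 100 ug/mL in this assay. The other two values are not read numbers; they sit at the limit of > 400 ug/mL in this assay, at which 2 of the 3 values shown sit. Compound 4 `CC(C)(C)OC(=O)C(O)Cn1cnc2c(N)ncnc21` carries tert-butyl in place of propyl on an oxygen next to a carbonyl group. The step bearing most directly on it is an at least 4.0-fold lower number from compound 2 to compound 3 (0.60 log units; beyond the scatter), with an at least 4.0-fold lower number from compound 1 to compound 3 (0.60 log units; beyond the scatter) also ending at compound 3. Since compound 2 with its branched group stood at the limit > 400 ug/mL, a move back toward higher tolerated concentration is expected. Compound 4 is therefore estimated at 300 ug/mL (range 100 ug/mL to 800 ug/mL). The step expected is a 3.0-fold higher number from compound 3 to compound 4 (0.48 log units; beyond the scatter).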

Compound 4, minimum cytotoxic concentration: > 400 ug/mL
Compound 4: only a limit was reported; the forecaster's own chance of this, stated with the estimate: 55%; middle value at least 1.3-fold (0.12 log units) from the limit.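

Tert-butyl in place of propyl on this oxygen gives an at least 4.0-fold higher number from compound 3 to compound 4 (0.60 log units; beyond the scatter) in this assay, which leaves compound 3 as the only member with a read number: the limit of > 400 ug/mL in this assay, at which 3 of the 4 values shown sit.

Isopropyl in compound 2 and tert-butyl in compound 4 both sit at that limit, but so does the 2-hydroxyethyl group of compound 1, which goes against any link to branching alone. The steps among compounds 1, 2 and 4 cannot be read, since each joins two limits.

Going by these compounds, how far compounds 1, 2 and 4 lie past the limit stays open. Also open, on these data alone, is whether a longer chain such as butyl, or a benzyl group, would read like propyl.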